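Replacing a ring on the core nitrogen of compound 1

A few compounds are considered here, and "the series" means these few. Any claim that something is new, unique, unknown or untested is made for them only; others in the source may bear on it.

Compound 1 `O=C(Cc1nn(C2CCNC2)c(=O)c2ccccc12)Nc1ccc(OC(F)(F)F)c(Cl)c1` belongs to a small set tested in a functional assay on CHO cells for antagonist activity at sphingosine 1-phosphate receptor 2 (Homo sapiens), read by calcium flux; on this read-out higher numbers stand for weaker inhibition and lower numbers for stronger inhibition. In this assay compound 1 gives 94 nM, the highest number among the three measured compounds. Compound 2 `C[C@@H](C(=O)O)c1nn(Cc2cn3cc(OCC4CC4)c(Cl)cc3n2)c2ccccc2c1=O` gives 24 nM in this assay, and compound 3 `CCC(C(=O)O)c1nn(Cc2cn3cc(OCC4CC4)c(Cl)cc3n2)c2ccccc2c1=O` gives 5.6 nM, so compound 1 is the weakest inhibitor of the three. Within the data shown here, the only single-point step among the measured compounds is a 4.3-fold lower number from compound 2 to compound 3 (0.63 log units; beyond the scatter); it concerns a carbon substituent on a different core and does not bear on the change examined here.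

Compound 4 `O=C(Cc1nn(CC(=O)N2CCOCC2)c(=O)c2ccccc12)Nc1ccc(OC(F)(F)F)c(Cl)c1` differs from compound 1 in one place: ((morpholin-4-yl)carbonyl)methyl in place of pyrrolidin-3-yl on an aromatic nitrogen. Among the measured compounds shown here, no measured pair shows what replacing the pyrrolidin-3-yl group on that nitrogen does, so nothing in the data points to a direction. The starting value of compound 1 in this assay and the absence of a guiding step together suggest that compound 4 is expected to stay near compound 1, with a wide range to either side; the expected shift is a 1.6-fold higher number from compound 1 to compound 4 (0.20 log units; within the scatter). For compound 4 the estimate in this assay is 150 nM, between 40 nM and 600 nM.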

Compound 4, half-maximal inhibitory concentration: 30 nM
Compound 4: the middle estimate sits 5.0-fold (0.70 log units) above what was measured; measured number outside the range, below it.
By their numbers in this assay, from the lowest: compound 3; then compounds 2 and 4 (each within the scatter of the next); then compound 1.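

In this assay, this nitrogen of the shared core accepts a much larger group without any loss, since the swap gives a 3.1-fold lower number from compound 1 to compound 4 (0.50 log units; beyond the scatter). The group that leaves carries 1 hydrogen-bond donor and the group that enters carries 0, so for this pair the donor of the pyrrolidin-3-yl ring is not needed to reach the lower number, and a group of 9 heavy atoms in place of one of 5 is compatible with stronger inhibition. Several things change at once here, namely the ring, the added carbonyl and the methyl link, and nothing available explains the improvement.

On these data alone, this single step cannot show which of these parts accounts for the shift, so it remains open whether a plain morpholin-4-yl group without the carbonyl, or a piperidine amide that lacks the ring oxygen, would give a similar number. A carboxylic acid on the same methyl link, or a longer chain between the carbonyl and the core nitrogen, would show whether the position responds to the carbonyl, the ring or simply the length of the group.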